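Adding a Methyl to a Polyamine Chain: Second Instance

The source may report more compounds than this note shows. Statements on the series, on what has been measured and on what is new or still open speak of the compounds shown alone.

Three polyamines have been compared so far. Compound 1, `CCNCCCNCCCCN`, is the smallest, and in a functional assay on L1210 cells (Mus musculus) for inhibition, with a stated time of 96 h (on this read-out lower numbers stand for stronger inhibition and higher numbers for weaker inhibition), compound 1 gives 4000 nM. Compound 3, `CCCNCCCNCCCCN`, carries one change relative to compound 1, (methyl in place of hydrogen on a saturated chain carbon, two bonds along the chain from an amine nitrogen), and in this assay compound 3 gives 28000 nM; this means a 7.0-fold higher number from compound 1 to compound 3 (0.85 log units; beyond the scatter). Compound 2, `CCNCCCCNCCCN`, is built from the same atoms as compound 1 joined differently; the difference between the two cores is not broken down here. In this assay compound 2 gives 40000 nM, which lies within the scatter of the number for compound 3 and is beyond the scatter above the number for compound 1.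

Compound 4, `CCCNCCCCNCCCN`, has not been measured. It differs from compound 2 by methyl in place of hydrogen on a saturated chain carbon, two bonds along the chain from an amine nitrogen, the same change that separates compound 1 from compound 3. Because that change produced a 7.0-fold higher number from compound 1 to compound 3 (0.85 log units; beyond the scatter), compound 4 is expected to show a step of similar direction and size, estimated as a 5.0-fold higher number from compound 2 to compound 4 (0.70 log units; beyond the scatter), though the weaker starting point of compound 2 makes the size less certain. Compound 4 is therefore estimated at 200000 nM in this assay, with a likely range from 60000 nM to 600000 nM.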

Compound 4, half-maximal inhibitory concentration: 55000 nM
Estimate against measurement, compound 4: 3.6-fold (0.56 log units) above; the whole stated range lies above it.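

In this assay, among these compounds, methyl in place of hydrogen on a saturated chain carbon, two bonds along the chain from an amine nitrogen, gives a 1.4-fold higher number from compound 2 to compound 4 (0.14 log units; within the scatter), so on the core of compound 2 this change produces no step that can be told from the scatter. Set beside the earlier step, the change does not carry over in size from one core to the other: the same change on two cores in this assay, a 7.0-fold higher number (0.85 log units; beyond the scatter) from compound 1 to compound 3 and a 1.4-fold higher number (0.14 log units; within the scatter) from compound 2 to compound 4, 5.1-fold (0.71 log units) apart, beyond the scatter of two such steps. These two pairs do not show why the cores part, and they give no rule for how the same change would behave on any further core in this series.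

The compounds shown leave open whether an ethyl group or a longer chain on that saturated chain carbon would also give different steps on the two cores. They also leave open whether a hydroxyl group or a carboxylic acid in that place would separate the cores in the same way.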